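Shrinking a Ring on a Sulfur-Linked Side Chain

A few compounds are considered here, and "the series" means these few. Any claim that something is new, unique, unknown or untested is made for them only; others in the source may bear on it.

For the measured compounds named here, compound 2 `c1ccc(-c2nc(SCCC3OCCCO3)[nH]c2-c2ccccc2)cc1` has the lower of the two numbers so far in an assay on microsomes from liver for inhibition of sterol O-acyltransferase 1 (Rattus norvegicus) (on this read-out higher numbers stand for weaker inhibition and lower numbers for stronger inhibition), but its only neighbour, compound 1 `O=C1CCCC(CSc2nc(-c3ccccc3)c(-c3ccccc3)[nH]2)O1`, lies within the scatter, so the two cannot be told apart. In this assay compound 1 gives 740 nM and compound 2 gives 730 nM. Going by the values given here, the single measured step, a 1.0-fold lower number from compound 1 to compound 2 (0.01 log units; within the scatter), swapped one six-membered ring for another on the saturated chain carbon bound to a sulfur and left the number essentially unchanged. Compound 3 `c1ccc(-c2nc(SCC3OCCO3)[nH]c2-c2ccccc2)cc1` alters the same position again: a group of 5 heavy atoms (3 carbon, 2 oxygen; one five-membered non-aromatic ring with 2 hetero atoms) in place of a group of 7 heavy atoms (5 carbon, 2 oxygen; one six-membered non-aromatic ring with 2 hetero atoms), on a saturated chain carbon bound to a sulfur. The measured step bears on this only loosely, since it compared two rings of equal size, whereas here a six-membered ring gives way to a five-membered one. With no evidence pointing either way, for compound 3 the expected step is a 1.1-fold higher number from compound 2 to compound 3 (0.04 log units; within the scatter), nothing beyond the scatter. Compound 3 is therefore estimated at 800 nM, between 350 nM and 1800 nM.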

Compound 3, half-maximal inhibitory concentration: 530 nM
Beside the measured number, compound 3's estimate is 1.5-fold (0.18 log units) above it; low and high end bracket the measured number.
By their numbers in this assay, from the lowest: compounds 3, 2 and 1 (each within the scatter of the next).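

Going from a six-membered ring to the smaller 1,3-dioxolan-2-yl group in this assay gives a 1.4-fold lower number from compound 2 to compound 3 (0.14 log units; within the scatter), and the comparison with the ring of compound 1 gives a 1.4-fold lower number from compound 1 to compound 3 (0.14 log units; within the scatter). The earlier pair compared only groups of equal heavy-atom count and equal ring size, whereas these steps show that a change in ring size and group size on a saturated chain carbon bound to a sulfur also stays within the scatter, so all three compounds remain indistinguishable here. Nothing available explains why these groups give such similar numbers.

From the compounds shown here alone, whether an amine or a carboxylic acid in place of these rings would give a number beyond the scatter remains open. So does the effect of a longer chain between the sulfur and the ring.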